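Shifting a Chlorine Atom on Compound 1

The source may hold more compounds than are shown below. What is called first, only, known or untested is meant among the compounds shown, and "the series" means these compounds.

Compound 1 `CC(C(=O)N1CCN(c2ccc(Cl)cc2)CC1)N1C(=O)CCC1=O` shows no measurable protection: in a functional assay on the whole organism (strain Swiss) with Mus musculus as the target, in the maximal electroshock model, with a stated time of 1 h, at a dose of 100 mg/kg by the intraperitoneal route (on this read-out lower numbers stand for a weaker effect and higher numbers for a stronger effect at the one dose given), compound 1 gives 0%. Compound 2 `CCC(C(=O)N1CCN(c2cccc(C(F)(F)F)c2)CC1)N1C(=O)CCC1=O` gives 0% in this assay, so compound 1 stands level with compound 2, with no difference beyond the usual scatter. Compound 3 `CC(C(=O)N1CCN(c2cccc(Cl)c2)CC1)N1C(=O)CCC1=O` differs from compound 1 in one place: 3-chlorophenyl in place of 4-chlorophenyl on an amine nitrogen in a ring. No measured step of this kind is available among these compounds, so the step from compound 1 to compound 3 is expected to stay within the scatter, with no change at the digits printed from compound 1 to compound 3 (within the scatter). For compound 3 the expected activity is 0%, estimated to lie between 0% and 15%.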

Compound 3, a percentage reported as activity, at one dose (the size of the read-out at that dose, not a potency): 50%
Estimate against measurement, compound 3: 50 percentage points below, and the stated range ends below it.
By their numbers in this assay, from the lowest: compounds 1 and 2 (each within the scatter of the next); then compound 3.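

In this assay, moving the chlorine atom to another place on the phenyl ring, with no atom gained or lost, gives a number 50 percentage points higher from compound 1 to compound 3 (beyond the scatter) for this change. For this pair, then, the read-out depends on where the chlorine sits, not only on which atoms are present. Nothing available explains why this shift has such an effect. On these data alone, it remains open whether another group at the same place, as in 3-fluorophenyl or 3-methoxyphenyl, would keep this protection. It is also unclear whether a 3-chlorophenyl group would do the same on a core with a longer chain.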